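Swapping an ester for methyl on the anilino ring

A few compounds are considered here, and "the series" means these few. Any claim that something is new, unique, unknown or untested is made for them only; others in the source may bear on it.

Measured in a functional assay on PC-3 cells (Homo sapiens) for inhibition, read by MTT assay, with a stated time of 48 h; on this read-out lower numbers stand for stronger inhibition and higher numbers for weaker inhibition:

- compound 1 `COc1cc(Nc2nc(Nc3ccc(Cl)cc3)nnc2Cl)cc(OC)c1OC`: 9610 nM
- compound 2 `COc1cc(Nc2nnc(Cl)c(Nc3cc(OC)c(OC)c(OC)c3)n2)cc(OC)c1OC`: 34300 nM
- compound 3 `CCOC(=O)c1ccc(Nc2nnc(Cl)c(Nc3cc(OC)c(OC)c(OC)c3)n2)cc1`: 58500 nM

In this assay compound 3 gives 58500 nM, and compound 2 gives 34300 nM. These two values lie within the scatter of each other. Both stand above the number of compound 1, which gives 9610 nM.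

The next compound is compound 4 `COc1cc(Nc2nc(Nc3ccc(C)cc3)nnc2Cl)cc(OC)c1OC`, which has not yet been measured. It keeps the core of compound 3 and carries methyl in place of ethoxycarbonyl on an aromatic carbon.

Going by the values given here, one measured step bears on this change: a 6.1-fold higher number from compound 1 to compound 3 (0.78 log units; beyond the scatter). There, ethoxycarbonyl took the place of chloro at the same spot on the same core. Read backwards, this step suggests that losing ethoxycarbonyl should lower the number by a modest amount. Among the compounds with values here, no measured compound carries methyl, so the data do not show how closely methyl will track chloro. Compound 4 differs from compound 1 only in that one group, so a value near that of compound 1 at 9610 nM is the natural expectation, with a wide margin.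

The expected change is a 4.5-fold lower number from compound 3 to compound 4 (0.65 log units; beyond the scatter), a modest fall in this assay. For compound 4 the estimated value is 13000 nM, with an expected range of 5000 nM to 32000 nM.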

Compound 4, half-maximal inhibitory concentration: 14300 nM
The estimate for compound 4 lay 1.1-fold (0.04 log units) below the measured number, within the range that was stated.
By their numbers in this assay, from the lowest: compounds 1 and 4 (each within the scatter of the next); then compounds 2 and 3 (each within the scatter of the next).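

In this assay, methyl in place of ethoxycarbonyl on the aromatic carbon para to a large group gives a 4.1-fold lower number from compound 3 to compound 4 (0.61 log units; beyond the scatter), a modest fall that goes beyond the scatter. The earlier compounds shown here had set ethoxycarbonyl against chloro alone, whereas this result sets it against a second group at the same spot, and in both comparisons ethoxycarbonyl carries the higher number. Methyl and chloro, however, cannot be told apart here, with a 1.5-fold higher number from compound 1 to compound 4 (0.17 log units; within the scatter) lying within the scatter, so at this position the assay separates ethoxycarbonyl from these two groups but not the two groups from each other, and nothing available accounts for that difference.

As far as these compounds go, whether an amine, a carboxylic acid or a longer chain at this spot would read like methyl and chloro or like ethoxycarbonyl remains open, and four compounds cannot settle it. From the compounds shown here alone, all of these values also come from this assay alone, so it stays open whether the same separation would appear in any other cell line or at any other exposure time.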